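The compounds below may be only part of what the source reports. "The series", "measured", "known", "first", "only" and "open" are said of these compounds alone.

Working notes on the series. Compound 1 `Cc1cn2c(/C=N/NC(=N)N)c(-c3ccncc3)nc2s1` sits second highest of the three numbers in a functional assay on colon cells (Homo sapiens) for antiproliferative activity (a lower number here means a stronger inhibitor of growth, a higher number a weaker inhibitor of growth), where compound 1 gives 15800 nM. Its nearest neighbour is compound 3 `N=C(N)N/N=C/c1c(-c2ccncc2)nc2sc(Cl)cn12`, which gives 8130 nM; the step of a 1.9-fold lower number from compound 1 to compound 3 (0.29 log units; within the scatter) does not leave the scatter. Compound 2 `Cc1sc2nc(-c3ccncc3)c(/C=N/NC(=N)N)n2c1C` gives 35500 nM, and the step of a 2.2-fold higher number from compound 1 to compound 2 (0.35 log units; beyond the scatter) is the only one in the set that does leave the scatter. Both measured steps alter the substituent on the five-membered ring of the shared core; neither touches the pyridyl group.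

Compound 4 `Cc1cn2c(/C=N/NC(=N)N)c(-c3ccccn3)nc2s1` differs from compound 1 only there: pyridin-2-yl in place of pyridin-4-yl on an aromatic carbon. Among the measured compounds shown here, no measured step in this assay bears on the position of the nitrogen in that six-membered ring, so the direction of the step is open and the expectation rests on compound 1 alone, with a wide range. Compound 4 is therefore estimated at 15000 nM, between 4000 nM and 60000 nM, meaning an expected step of a 1.1-fold lower number from compound 1 to compound 4 (0.02 log units; within the scatter), no larger than the scatter.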

Compound 4, concentration for 50% growth inhibition: 8130 nM
Estimate against measurement, compound 4: 1.8-fold (0.27 log units) above; the range from low to high includes it.
By their numbers in this assay, from the lowest: compounds 3, 4 and 1 (each within the scatter of the next); then compound 2.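

In this assay, among the compounds shown here, pyridin-2-yl in place of pyridin-4-yl gives a 1.9-fold lower number from compound 1 to compound 4 (0.29 log units; within the scatter), the first reading of a change at this aromatic carbon rather than on the five-membered ring bearing the methyl group. The position of the nitrogen in the six-membered ring therefore shows no effect that can be separated from the scatter in this pair, and pyridin-4-yl is not required to keep the number in the range of compound 1. Nothing available explains this result or bears on it.

As far as these compounds go, what pyridin-3-yl or an unsubstituted phenyl would give at this place remains open. From the compounds shown here alone, it is also open whether the step seen with pyridin-2-yl would hold on the chloro core of compound 3 or the dimethyl core of compound 2.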